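Ring amine replaces methylamino on the acetyl chain

The source may report more compounds than this note shows. Statements on the series, on what has been measured and on what is new or still open speak of the compounds shown alone.

Compounds measured so far:
compound 1, `CC1=NN(C(=O)CN2CCCCC2)C(c2ccccc2O)C1`, 4310 nM;
compound 2, `CC1=NN(C(=O)CN2CCC(c3ccccc3)CC2)C(c2ccccc2O)C1`, 12300 nM;
compound 3, `CNCC(=O)N1N=C(c2cc3ccccc3oc2=O)CC1c1ccccc1`, 12800 nM.

In a functional assay on MGC-803 cells (Homo sapiens) for cytotoxicity, read by MTT assay, with a stated time of 48 h (on this read-out lower numbers stand for stronger inhibition and higher numbers for weaker inhibition), compound 3 gives the highest of the three numbers, yet the gap to compound 2 lies within the scatter, while compound 1 sits clearly lower. Compound 4, `CC1CCCN(CC(=O)N2N=C(c3cc4ccccc4oc3=O)CC2c2ccccc2)C1`, differs from compound 3 by one change: 3-methylpiperidin-1-yl in place of methylamino on a saturated chain carbon bound to a carbonyl carbon. Within the data shown here, no measured pair shows this exact exchange. Among the measured compounds shown here, the only measured step, a 2.9-fold higher number from compound 1 to compound 2 (0.46 log units; beyond the scatter), concerns a substituent on the same kind of saturated ring and is modest. Compounds 1 and 2 both carry a ring amine on the acetyl chain, and compound 1 gives a lower number than compound 3, so the step is expected to be a modest lowering, a 1.8-fold lower number from compound 3 to compound 4 (0.26 log units; within the scatter), though it could stay within the scatter. Compound 4 is therefore estimated at 7000 nM, with a range from 2500 nM to 20000 nM.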

Compound 4, half-maximal inhibitory concentration: "not active" (no number reported)
For compound 4 the study gives words and no number, and the estimate cannot be compared.
By their numbers in this assay, from the lowest: compound 1; then compounds 2 and 3 (each within the scatter of the next).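

Among these compounds, compound 4 is reported only in words, as "not active", with no number, so no step from compound 3 to compound 4 can be read. No further data bear on this result. The compounds shown leave open how far 3-methylpiperidin-1-yl in place of methylamino shifts the number on this core.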